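The source may hold more compounds than are shown below. What is called first, only, known or untested is meant among the compounds shown, and "the series" means these compounds.

In a functional assay on A2780 cells (Homo sapiens) for inhibition, with a stated time of 72 h (on this read-out lower numbers stand for stronger inhibition and higher numbers for weaker inhibition), compound 1 `CC1(C)CCNc2ccc(NC(=S)Nc3ccc(C(F)(F)F)cc3)cc21` gives 6000 nM, compound 2 `CN1c2ccc(NC(=S)Nc3ccc([N+](=O)[O-])cc3)cc2C(C)(C)C(O)C1(C)C` gives 10000 nM and compound 3 `CN1c2ccc(NC(=S)Nc3ccc(C(F)(F)F)cc3)cc2C(C)(C)C(O)C1(C)C` gives 7600 nM. Compound 3 therefore stands within the scatter of both other compounds. Compound 4 `CN1c2ccc(NC(=S)Nc3ccc(OC(F)(F)F)cc3)cc2C(C)(C)C(O)C1(C)C` carries trifluoromethoxy in place of trifluoromethyl on an aromatic carbon, para to a large group: trifluoromethoxy in place of trifluoromethyl on an aromatic carbon. Within the data shown here, one measured step bears on this carbon, with trifluoromethyl in place of nitro: a 1.3-fold lower number from compound 2 to compound 3 (0.12 log units; within the scatter). That exchange stayed within the scatter, so no shift beyond the scatter is expected in this assay for the new group, although no measurement of it exists yet. An estimated 1.1-fold lower number from compound 3 to compound 4 (0.04 log units; within the scatter) is expected. The expected value for compound 4 is 7000 nM, with an estimated range of 3500 nM to 14000 nM.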

Compound 4, half-maximal inhibitory concentration: 13100 nM
The estimate for compound 4 lay 1.9-fold (0.27 log units) below the measured number; the range from low to high includes it.
By their numbers in this assay, from the lowest: compounds 1, 3, 2 and 4 (each within the scatter of the next, the first and the last beyond it).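

In this assay the trifluoromethoxy group on this aromatic carbon gives a 1.7-fold higher number from compound 3 to compound 4 (0.24 log units; within the scatter) and also a 1.3-fold higher number from compound 2 to compound 4 (0.12 log units; within the scatter). Nitro, trifluoromethyl and trifluoromethoxy at this place therefore stay within the scatter of one another, so the extra oxygen brings no change beyond the scatter. No evidence is available to account for these small steps. From the compounds shown here alone, whether an amine, a carboxylic acid or a longer chain on this carbon would move the number beyond the scatter remains open. So does whether trifluoromethoxy would behave the same way on the core of compound 1.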